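Prop-1-en-1-yl for 2-methylprop-1-en-1-yl on two cores

The source may hold more compounds than are shown below. What is called first, only, known or untested is meant among the compounds shown, and "the series" means these compounds.

Compound 1, `COc1cc2ncnc(N3CCc4ccccc43)c2cc1NC(=O)C=C(C)C`: 7840 nM
Compound 2, `C/C=C/C(=O)Nc1cc2c(N3CCc4ccccc43)ncnc2cc1OC`: 8120 nM
Compound 3, `CC(C)=CC(=O)Nc1cc2c(N3CCCc4ccccc43)ncnc2cc1O[C@@H]1CCOC1`: 9020 nM

In a functional assay on PC-3 cells (Homo sapiens) for antiproliferative activity, read by MTT assay, with a stated time of 72 h (on this read-out higher numbers stand for weaker inhibition and lower numbers for stronger inhibition), compound 1 and compound 2 differ by prop-1-en-1-yl in place of 2-methylprop-1-en-1-yl on a carbonyl carbon, a change that made a 1.0-fold higher number from compound 1 to compound 2 (0.02 log units; within the scatter). Compound 3 carries a different core; the difference between the two cores is not broken down here. Compound 4, `C/C=C/C(=O)Nc1cc2c(N3CCCc4ccccc43)ncnc2cc1O[C@@H]1CCOC1`, has not yet been measured and differs from compound 3 by prop-1-en-1-yl in place of 2-methylprop-1-en-1-yl on a carbonyl carbon, the same change at the same kind of place. Because the earlier step came out as a 1.0-fold higher number from compound 1 to compound 2 (0.02 log units; within the scatter), the estimated step is a 1.0-fold lower number from compound 3 to compound 4 (0.00 log units; within the scatter). Compound 4 is therefore expected to give 9000 nM in this assay, with a likely range from 5000 nM to 16000 nM.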

Compound 4, half-maximal inhibitory concentration: 9350 nM
The estimate for compound 4 lay 1.0-fold (0.02 log units) below the measured number; the range from low to high includes it.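

Replacing 2-methylprop-1-en-1-yl with prop-1-en-1-yl on the carbonyl carbon gave a 1.0-fold higher number from compound 3 to compound 4 (0.02 log units; within the scatter) in this assay. On both cores the change left the number within the scatter, and the two steps agree: the same change on two cores in this assay, a 1.0-fold higher number (0.02 log units; within the scatter) from compound 1 to compound 2 and a 1.0-fold higher number (0.02 log units; within the scatter) from compound 3 to compound 4, 1.0-fold (0.00 log units) apart, within the scatter of two such steps. This shows that the swap behaved alike on these two cores, but it does not show that it would do so on a third, nor how a step large enough to read would carry from one core to another.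

From the compounds shown here alone, whether a different group on that carbonyl carbon, such as an amine-bearing chain or a carboxylic acid, would move the number remains open. So does the contribution of the difference between the two cores.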